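Fluorine on a Phenyl Ring in Two Related Cores

The source may report more compounds than this note shows. Statements on the series, on what has been measured and on what is new or still open speak of the compounds shown alone.

Measured compounds:
compound 1, `c1ccc(-[n+]2c[nH]c3ncncc32)cc1`: 0%
compound 2, `Fc1ccc(-[n+]2c[nH]c3ncncc32)cc1`: 2%
compound 3, `c1ccc(C[n+]2c[nH]c3ncncc32)cc1`: 7%

All three were tested in an assay on isolated protein for inhibition of Rho-associated protein kinase 1 (Homo sapiens), tested at 30 uM; on this read-out lower numbers stand for less inhibition and higher numbers for more inhibition at the one concentration tested (going by the name of the read-out). Compound 1 and compound 2 share a core and differ by fluoro in place of hydrogen on an aromatic carbon; this gave a number 2 percentage points higher from compound 1 to compound 2 (within the scatter). Compound 3 carries a different core; how its core differs from that of compound 1 is not broken down here. Its value and the values of compound 1 and compound 2 all lie within the usual scatter of one another.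

Compound 4, `Fc1ccc(C[n+]2c[nH]c3ncncc32)cc1`, is not yet measured. It differs from compound 3 by fluoro in place of hydrogen on an aromatic carbon, the same kind of change as from compound 1 to compound 2, although here the place is para to a large group rather than para to a group of 9 heavy atoms.

Compound 4 is expected to give about 9% in this assay, plausibly between 0% and 20%. This amounts to an expected step of a number 2 percentage points higher from compound 3 to compound 4 (within the scatter), which rests on the earlier step of a number 2 percentage points higher from compound 1 to compound 2 (within the scatter).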

Compound 4, a percentage reported as inhibition, at one concentration (the size of the read-out at that concentration, not a potency): 4%
Compound 4: middle estimate off by 5 percentage points, on the high side, within the range that was stated.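

In this assay, fluoro in place of hydrogen on the aromatic ring gave a number 3 percentage points lower from compound 3 to compound 4 (within the scatter). Set beside the earlier step, the two cores cannot be told apart for this change: the same change on two cores in this assay, a number 2 percentage points higher (within the scatter) from compound 1 to compound 2 and a number 3 percentage points lower (within the scatter) from compound 3 to compound 4, 5 percentage points apart, within the scatter of two such steps This shows no sign that the core alters the effect of fluoro, but it does not show that the effect carries over, since neither step can be told from scatter and all four compounds show little inhibition, leaving hardly any effect to carry.

Going by these compounds, it remains open whether a different group on that ring, such as an amine, a carboxylic acid or a longer chain, would give a step beyond the scatter. On these data alone, it also remains open what fluoro would do elsewhere on the ring.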